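Working notes: microsomal stability of four analogues

This account rests on a few compounds, and the source may have more. Where it says the series, first, only, none or still open, it means among the compounds named here.

Measured compounds:
compound 1, `FC(F)(F)c1ccccc1-c1ccc2[nH]c(C3=NOC4(CCCCC4)C3)nc2c1`, 100%
compound 2, `FC(F)(F)Oc1ccccc1-c1ccc2[nH]c(C3=NOC4(CCCCC4)C3)nc2c1`, 100%
compound 3, `Fc1cccc(C(F)(F)F)c1-c1ccc2[nH]c(C3=NOC4(CCCCC4)C3)nc2c1`, 38%

In an ADME assay on microsomes from liver (Homo sapiens) for metabolic stability, with a stated time of 10 min (a lower number here means that less of the compound is left, a higher number that more of the compound is left), compound 1 gives 100%. Compound 2 differs by trifluoromethoxy in place of trifluoromethyl on an aromatic carbon and gives 100% in this assay, so no change at the digits printed from compound 1 to compound 2 (within the scatter). Compound 3 differs from compound 1 by fluoro in place of hydrogen on an aromatic carbon; here a number 62 percentage points lower from compound 1 to compound 3 (beyond the scatter).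

Compound 4, `Fc1cccc(OC(F)(F)F)c1-c1ccc2[nH]c(C3=NOC4(CCCCC4)C3)nc2c1`, is not yet measured in this assay. It differs from compound 3 by trifluoromethoxy in place of trifluoromethyl on an aromatic carbon, the same kind of change as that from compound 1 to compound 2, but with the place also described as meta to a fluoro group (1 heavy atom). The step from compound 3 to compound 4 is expected to be small, a number 2 percentage points higher from compound 3 to compound 4 (within the scatter), because the earlier change gave no change at the digits printed from compound 1 to compound 2 (within the scatter). That earlier pair sits at the top of the scale, so the transfer is uncertain. Compound 4 is estimated at 40%, expected between 18% and 68%.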

Compound 4, percent of the compound remaining: 100%
Compound 4: middle estimate off by 60 percentage points, on the low side; the whole stated range lies below it.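

In this assay, trifluoromethoxy in place of trifluoromethyl gives a number 62 percentage points higher from compound 3 to compound 4 (beyond the scatter), so the step seen on the core of compound 1 does not carry over to the core of compound 3: the same change on two cores in this assay, no change at the digits printed (within the scatter) from compound 1 to compound 2 and a number 62 percentage points higher (beyond the scatter) from compound 3 to compound 4, 62 percentage points apart, beyond the scatter of two such steps. Fluoro in place of hydrogen also depends on the core, with no change at the digits printed from compound 2 to compound 4 (within the scatter): the same change on two cores in this assay, a number 62 percentage points lower (beyond the scatter) from compound 1 to compound 3 and no change at the digits printed (within the scatter) from compound 2 to compound 4, 62 percentage points apart, beyond the scatter of two such steps. Of these four compounds, only compound 3 falls away from the top of the scale; this shows that neither change can be transferred here as a fixed step, but it does not show why, or what either change would do on any other core.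

The compounds shown leave open whether this dependence extends to other groups, such as a nitrile or a methoxy group in place of trifluoromethoxy. Going by these compounds, a chloro group in place of fluoro is likewise open.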